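Methyl to chloro on the fused core: metabolic stability

The compounds below may be only part of what the source reports. "The series", "measured", "known", "first", "only" and "open" are said of these compounds alone.

Measured compounds:
- compound 1, `CC#C[C@@H](Cc1nnn[nH]1)c1ccc(OCc2cc(C)c3scc(-c4ccccc4C)c3c2)cc1`: < 0.0667 h in an ADME assay on microsomes from liver (Homo sapiens) for metabolic stability; on this read-out higher numbers stand for a longer-lived compound and lower numbers for a shorter-lived compound
- compound 2, `CC#C[C@@H](Cc1nnn[nH]1)c1ccc(OCc2ccc3scc(C4CC4)c3c2)cc1`: 0.267 h in this assay

In this assay compound 1 gives < 0.0667 h, which is a limit of the assay and not a number. Compound 2 gives a measured value in this assay. Compound 1 therefore sits at the limit of < 0.0667 h in this assay, at which 1 of the 2 values shown sits, and where it truly lies cannot be placed on these numbers.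

Compound 3, `CC#C[C@@H](Cc1nnn[nH]1)c1ccc(OCc2cc(Cl)c3scc(-c4ccccc4C)c3c2)cc1`, is not yet measured. It differs from compound 1 by chloro in place of methyl on an aromatic carbon. Among the compounds with values here, no measured step between two compounds is available to size such an exchange.

With compound 1 resting at a limit, the expected step that the limit leaves unreadable from compound 1 to compound 3 is taken as none beyond the scatter. Compound 3 is thus expected to give 0.06 h in this assay, within a range from 0.03 h to 0.15 h.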

Compound 3, half-life: 0.217 h
The estimate for compound 3 lay 3.6-fold (0.56 log units) below the measured number, and the stated range ends below it.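

Chloro in place of methyl on an aromatic carbon, ortho to a fused ring, is the first exchange at this position that can be sized in this assay, and it gives an at least 3.2-fold higher number from compound 1 to compound 3 (0.51 log units; beyond the scatter). The read-out at this position of the shared core therefore responds to the exchange of a single heavy atom, and compound 3 gives 0.217 h, a measured value. The step is a lower bound only, as compound 1 rests at a limit of the assay and not at a number: the limit of < 0.0667 h in this assay, at which 1 of the 3 values shown sits.

Open is whether the gain belongs to chloro itself or to the loss of methyl, as hydrogen, fluoro, methoxy and nitrile at this position do not stand among the compounds shown. Also open, on these data alone, is whether the same exchange gives a like step elsewhere.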